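From ethoxy to chloro: what compound 3 may show

A few compounds are considered here, and "the series" means these few. Any claim that something is new, unique, unknown or untested is made for them only; others in the source may bear on it.

Compound 1 `COC(=O)N1N=C(c2ccccc2)CC1c1cc(OC)c(OC)c(OC)c1`: 3950 nM
Compound 2 `CCOc1cccc(C2=NN(C(=O)OC)C(c3cc(OC)c(OC)c(OC)c3)C2)c1`: 8360 nM

In a functional assay on HepG2 cells (Homo sapiens) for antiproliferative activity, read by MTT assay, with a stated time of 48 h (a lower number here means a stronger inhibitor of growth, a higher number a weaker inhibitor of growth), compound 2 has the higher number of the two. Compound 3 `COC(=O)N1N=C(c2cccc(Cl)c2)CC1c1cc(OC)c(OC)c(OC)c1` has chloro in place of ethoxy on an aromatic carbon. Going by the values given here, the one measured step that bears on this is a 2.1-fold higher number from compound 1 to compound 2 (0.33 log units; beyond the scatter), for ethoxy in place of hydrogen on an aromatic carbon. Among the compounds with values here, no chloro compound has been measured, so any forecast is uncertain. With ethoxy gone, a result nearer compound 1, at 3950 nM, seems likely. A modest drop is expected, namely a 1.9-fold lower number from compound 2 to compound 3 (0.27 log units; within the scatter). The estimate for compound 3 is 4500 nM, with an expected range of 1800 nM to 11000 nM.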

Compound 3, concentration for 50% growth inhibition: 1240 nM
For compound 3 the middle estimate is 3.6-fold (0.56 log units) above the measured one, outside the stated range (below it).
By their numbers in this assay, from the lowest: compound 3; then compound 1; then compound 2.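

In this assay, going from 3-ethoxyphenyl to 3-chlorophenyl gives a 6.7-fold lower number from compound 2 to compound 3 (0.83 log units; beyond the scatter) and chloro in place of hydrogen gives a 3.2-fold lower number from compound 1 to compound 3 (0.50 log units; beyond the scatter). This position therefore does not simply penalise any added group: ethoxy raised the number, whereas chloro lowers it beyond what hydrogen gives. No measurement here explains why these two groups differ. Going by these compounds, whether an amine, a hydroxyl or a methyl group at this place would behave more like chloro or more like ethoxy stays open. Three compounds are too few to support a trend across groups.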